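Amide nitrogen substitution on the shared core

A few compounds are considered here, and "the series" means these few. Any claim that something is new, unique, unknown or untested is made for them only; others in the source may bear on it.

Two compounds of the series have been run in a functional assay on the whole organism (strain Swiss albino) for inhibition, with Mus musculus as the target, in the writhing test, with stated times of 60 min and 15 min, at a dose of 100 mg/kg by the oral route; a lower number here means less inhibition, a higher number more inhibition at the dose given (going by the name of the read-out). Compound 1 `CCNC(=O)CC1CCc2cc(OC)c(OC)cc21` carries a single ethyl on the amide nitrogen, and in this assay compound 1 gives 23.6%. Compound 2 `CCN(CC)C(=O)CC1CCc2cc(OC)c(OC)cc21` carries two ethyls there, and in this assay compound 2 gives 27.4%. Among the measured compounds shown here, the only measured step, a number 3.8 percentage points higher from compound 1 to compound 2 (within the scatter), is within the scatter, so the numbers of compound 1 and compound 2 cannot be told apart on this evidence; compound 2 simply sits alongside compound 1 as one of two closely placed results.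

Compound 3 `CCCNC(=O)CC1CCc2cc(OC)c(OC)cc21` is not yet measured. Relative to compound 2 it shows (propylamino in place of diethylamino on a carbonyl carbon). For the measured compounds named here, the one step that bears on a change at the amide nitrogen is a number 3.8 percentage points higher from compound 1 to compound 2 (within the scatter), which was small, and it gives no sign that rearranging the carbons on this nitrogen moves the read-out in this assay beyond the scatter. The step from compound 2 to compound 3 is therefore expected to be a number 2.4 percentage points lower from compound 2 to compound 3 (within the scatter), with no clear direction. Compound 3 is estimated to give 25% in this assay, with a range from 12% to 38%.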

Compound 3, a percentage reported as inhibition, in the whole organism at one dose (the size of the read-out at that dose, not a potency): 26.9%
Compound 3: the middle estimate sits 1.9 percentage points below what was measured, within the range that was stated.
By their numbers in this assay, from the lowest: compounds 1, 3 and 2 (each within the scatter of the next).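

Within this assay, the step of a number 0.5 percentage points lower from compound 2 to compound 3 (within the scatter) is within the scatter, although propylamino brings one hydrogen-bond donor where diethylamino has none and carries one heavy atom fewer, so neither difference separates the two compounds at this dose. The step of a number 3.3 percentage points higher from compound 1 to compound 3 (within the scatter) adds a second reading at the same nitrogen, this time for methyl in place of hydrogen on a saturated chain carbon, two bonds along the chain from an amide-type nitrogen, and it too lies within the scatter, so compound 1, compound 2 and compound 3 cannot be told apart on this read-out. No separate evidence bears on these results.

Still open, from the compounds shown here alone, is whether a longer chain such as hexyl, or a benzyl group or piperidine ring on this nitrogen, would shift the number beyond the scatter. Also open, going by these compounds, is whether a carboxylic acid or an amine in place of the amide would do so, and because each value comes from a single dose, none of this gives a potency.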